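The source may hold more compounds than are shown below. What is called first, only, known or untested is meant among the compounds shown, and "the series" means these compounds.

Working notes on the series, read-out throughout: a functional assay on cells (T-cell line, Homo sapiens) for inhibition; on this read-out higher numbers stand for weaker inhibition and lower numbers for stronger inhibition

- compound 1 `COc1ccccc1CCCN1CCC(COC(c2ccccc2)c2ccccc2)CC1` gives 2400 nM
- compound 2 `Clc1ccccc1CCCN1CCC(COC(c2ccccc2)c2ccccc2)CC1` gives 800 nM
- compound 3 `CCCCCCN1CCC(COC(c2ccccc2)c2ccccc2)CC1` gives 5500 nM

Compound 3 has the highest number of the three, so it is the weakest inhibitor measured so far. The next change gives compound 4 `C(#Cc1ccccc1)CN1CCC(COC(c2ccccc2)c2ccccc2)CC1`, with 2-phenylethynyl in place of pentyl on a saturated chain carbon bound to an amine nitrogen in a ring.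

The closest evidence is the pair of steps that remove an aromatic ring from the chain (a 2.3-fold higher number from compound 1 to compound 3 (0.36 log units; beyond the scatter)) and (a 6.9-fold higher number from compound 2 to compound 3 (0.84 log units; beyond the scatter)). Both raise the number, so restoring a ring should lower it. The ring substituent also counts (a 3.0-fold lower number from compound 1 to compound 2 (0.48 log units; beyond the scatter)), and compound 4 carries neither chloro nor methoxy. Going by the values given here, no measured compound has a triple bond, which widens the uncertainty.

The expected step (a 2.8-fold lower number from compound 3 to compound 4 (0.44 log units; beyond the scatter)) is a modest move to a lower number, though one that may not clear the scatter. For compound 4 the estimated value is 2000 nM, with an expected range from 700 nM to 5500 nM.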

Compound 4, half-maximal inhibitory concentration: > 20000 nM
Compound 4: no number, only a limit (the forecaster's own chance of this, stated with the estimate: 5%); middle value at least 10-fold (1.00 log units) away from the limit.
By their numbers in this assay, from the lowest: compound 2; then compound 1; then compound 3. At a limit, above all of these: compound 4.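

In this assay the result for compound 4 is a limit and not a number: the limit of > 20000 nM in this assay, at which 1 of the 4 values shown sits.

An aromatic ring on this chain therefore does not lower the number by itself: 2-phenylethynyl in place of pentyl gives an at least 3.6-fold higher number from compound 3 to compound 4 (0.56 log units; beyond the scatter), the reverse of what the earlier ring-removing steps suggested. The gap is wider against the chains that carry a substituted ring and no triple bond, with an at least 25-fold higher number from compound 2 to compound 4 (1.39 log units; beyond the scatter) and an at least 8.3-fold higher number from compound 1 to compound 4 (0.92 log units; beyond the scatter).

The compounds shown do not separate the triple bond from the loss of the chloro or methoxy substituent, since both differences arrive together in compound 4. A plain 3-phenylpropyl chain, or a 3-(2-chlorophenyl)prop-2-yn-1-yl group, in the same place would tell these two apart.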